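A few compounds are considered here, and "the series" means these few. Any claim that something is new, unique, unknown or untested is made for them only; others in the source may bear on it.

Measured so far in a functional assay on PC-3 cells (Homo sapiens) for cytotoxicity, read by MTT assay, with a stated time of 72 h; a lower number here means a stronger inhibitor, a higher number a weaker inhibitor: compound 1 `[O-][n+]1nc(NCOC2CCCCC2)[n+]([O-])c2ccccc21` gives 3250 nM; compound 2 `O=[N+]([O-])c1cccc(COCNc2n[n+]([O-])c3ccccc3[n+]2[O-])c1` gives 3070 nM; compound 3 `CCCCCOCNc1n[n+]([O-])c2ccccc2[n+]1[O-]` gives 9200 nM.

Compound 3 thus carries the highest number of the three, with compound 1 nearest and compound 2 a little further away. Compound 4 `[O-][n+]1nc(NCOCc2ccccc2)[n+]([O-])c2ccccc21` differs from compound 3 by phenyl in place of butyl on a saturated chain carbon bound to an oxygen on a saturated carbon. Going by the values given here, the only measured step touching this spot is a 2.8-fold higher number from compound 1 to compound 3 (0.45 log units; beyond the scatter), where a cyclohexyl gave way to a pentyl and the number rose. Returning a ring in the shape of a phenyl is therefore expected to bring the number down again, and the value of compound 2, which also holds an aromatic ring at this end, points the same way. Compound 4 is accordingly estimated at 3200 nM, within a range from 1500 nM to 7000 nM. The expected step is a 2.9-fold lower number from compound 3 to compound 4 (0.46 log units; beyond the scatter).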

Compound 4, half-maximal inhibitory concentration: 13400 nM
Compound 4: the middle estimate sits 4.2-fold (0.62 log units) below what was measured; the whole stated range lies below it.
By their numbers in this assay, from the lowest: compounds 2 and 1 (each within the scatter of the next); then compounds 3 and 4 (each within the scatter of the next).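

In this assay, an aromatic ring at this end does not by itself lower the number: phenyl in place of butyl leaves the two compounds within the scatter (a 1.5-fold higher number from compound 3 to compound 4 (0.16 log units; within the scatter)). Plain benzyl in place of cyclohexyl does raise it (a 4.1-fold higher number from compound 1 to compound 4 (0.62 log units; beyond the scatter)), and so does hydrogen in place of nitro on the aromatic carbon (a 4.4-fold higher number from compound 2 to compound 4 (0.64 log units; beyond the scatter)), so the ring alone does not account for the number of compound 2. No measurement here explains these steps. Still open, from the compounds shown here alone, is whether an amine or a methoxy group in place of that nitro would also give a lower number, and how a longer chain in place of pentyl would read.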